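Adding a Nitro Group to a Series Without Measurable Inhibition

The source may report more compounds than this note shows. Statements on the series, on what has been measured and on what is new or still open speak of the compounds shown alone.

Compound 1, `Nc1ccc2c(c1)C(=O)N(CCNc1ccccc1)C2=O`: > 200000 nM
Compound 2, `O=C1c2ccccc2C(=O)N1CCNc1ccccc1`: > 200000 nM

In an assay on isolated protein for inhibition of lactase/phlorizin hydrolase (Rattus norvegicus), read by colorimetric assay (a lower number here means a stronger inhibitor, a higher number a weaker inhibitor), compound 1 gives > 200000 nM, which is a limit of the assay rather than a number. Compound 2 gives > 200000 nM, again only a limit. Within the data shown here, the only measured step, a step that the two limits leave unreadable from compound 1 to compound 2, cannot be read in size or direction because both of its ends sit at the limit of > 200000 nM in this assay, at which 2 of the 2 values shown sit. So compound 2 stands only at the limit, and no measured step shows how a change on its aromatic ring moves the read-out.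

Compound 3, `O=C1c2ccc([N+](=O)[O-])cc2C(=O)N1CCNc1ccccc1`, differs from compound 2 by nitro in place of hydrogen on an aromatic carbon. Among the measured compounds shown here, no measured step bears on this change, since the one step that exists is unreadable. With compound 2 itself at the limit, the most likely outcome is that compound 3 also falls at or beyond that limit, and any movement within a readable range would be a surprise. Compound 3 is therefore expected to give about 300000 nM, within a range from 50000 nM to 2000000 nM. This expectation corresponds to an estimated step that the limit leaves unreadable from compound 2 to compound 3.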

Compound 3, half-maximal inhibitory concentration: > 200000 nM
Compound 3: only a limit was reported; the forecaster's own chance of this, stated with the estimate: 85%; the middle value lies beyond the limit too.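

In this assay compound 3 gives > 200000 nM, which is a limit of the assay and not a number. The steps joining compound 3 to compound 1 and compound 2 cannot be read, because all three compounds sit at the same limit: the limit of > 200000 nM in this assay, at which 3 of the 3 values shown sit.

The compounds shown leave open whether any change on this aromatic ring can bring inhibition into a measurable range.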